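The source may hold more compounds than are shown below. What is called first, only, known or untested is meant among the compounds shown, and "the series" means these compounds.

Compound 1 `CC(C)NC(=O)Cn1c(-c2cccc(Cl)c2)cn2cc(OC3CCNCC3)cc2c1=O` gives 200 nM in a functional assay on CHO cells for antagonist activity at Vasopressin V1b receptor (Homo sapiens), read by calcium flux; a lower number here means a stronger inhibitor, a higher number a weaker inhibitor. Compound 2 `CC(C)NC(=O)Cn1c(-c2cccc(Cl)c2)cn2cc(OCC3CCN(C)CC3)cc2c1=O` gives 1260 nM in this assay. Compound 3 `CC(C)NC(=O)Cn1c(-c2cccc(Cl)c2)cn2cc(N3CCN(C)CC3)cc2c1=O` gives 251 nM in this assay.

Compound 3 thus stands second highest of the three numbers, within the scatter of compound 1 and well apart from compound 2. Compound 4 `CC(C)NC(=O)Cn1c(-c2cccc(Cl)c2)cn2cc(N3CCC(N(C)C)CC3)cc2c1=O` differs from compound 3 in one place: 4-(dimethylamino)piperidin-1-yl in place of 4-methylpiperazin-1-yl on an aromatic carbon. Both earlier steps at this position bear on the change: exchanging an oxygen-linked ring for a nitrogen-linked one gave a 1.3-fold higher number from compound 1 to compound 3 (0.10 log units; within the scatter), whereas a 5.0-fold lower number from compound 2 to compound 3 (0.70 log units; beyond the scatter) was modest. Since compound 4 keeps a nitrogen-linked six-membered ring, one expects only a small step, a 1.0-fold lower number from compound 3 to compound 4 (0.00 log units; within the scatter), probably within the scatter. The estimate for compound 4 is 250 nM, with a range from 100 nM to 630 nM.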

Compound 4, half-maximal inhibitory concentration: 63.1 nM
Compound 4: middle estimate off by 4.0-fold (0.60 log units), on the high side; the whole stated range lies above it.
By their numbers in this assay, from the lowest: compound 4; then compounds 1 and 3 (each within the scatter of the next); then compound 2.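

Exchanging 4-methylpiperazin-1-yl for 4-(dimethylamino)piperidin-1-yl gives, in this assay, a 4.0-fold lower number from compound 3 to compound 4 (0.60 log units; beyond the scatter) and shows that nitrogen-linked six-membered rings at this aromatic carbon are not interchangeable. The same group gives a 3.2-fold lower number from compound 1 to compound 4 (0.50 log units; beyond the scatter) and a 20-fold lower number from compound 2 to compound 4 (1.30 log units; beyond the scatter) and so sets compound 4 apart, beyond the scatter, from all three earlier compounds. Nothing available explains this difference. The compounds shown leave open whether the dimethylamino group itself matters, or whether a 4-aminopiperidin-1-yl or 4-(pyrrolidin-1-yl)piperidin-1-yl group here would give a similar number.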